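The compounds below may be only part of what the source reports. "The series", "measured", "known", "first", "only" and "open" are said of these compounds alone.

In an ADME assay on Raji cells (Homo sapiens) for cytotoxicity, read by luminescence, with a stated time of 72 h (a lower number here means that less compound is needed, a higher number that more compound is needed for the effect), only limits are available so far, and a limit is not a number. Compound 1 `CCOC(=O)c1c(-c2cccc(-c3ccccc3)c2)[nH]c2cc(OC)c(F)cc2c1=O` gives > 21500 nM, which is a limit of the assay. Compound 2 `CCOC(=O)c1c(-c2cccc(OC)c2)[nH]c2cc(OC)c(F)cc2c1=O` gives > 21500 nM, also a limit. Compound 3 `CCOC(=O)c1c(-c2cccc(Oc3c(C)cccc3C)c2)[nH]c2cc(OC)c(F)cc2c1=O` gives > 21500 nM, again a limit, so its position is known only as a limit and not as a point on the scale.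

Compound 4 `CCOC(=O)c1c(-c2cccc(-c3nc(C)c(C)s3)c2)[nH]c2cc(OC)c(F)cc2c1=O` differs from compound 3 in one place: 4,5-dimethyl-1,3-thiazol-2-yl in place of 2,6-dimethylphenoxy on an aromatic carbon. The measured changes at this same place are a step that the two limits leave unreadable from compound 1 to compound 3, a step that the two limits leave unreadable from compound 2 to compound 3 and a step that the two limits leave unreadable from compound 1 to compound 2. None of them gives a size that can be carried over to the new change. What they do show together is the limit of > 21500 nM in this assay, at which 3 of the 3 values shown sit.

Three different groups at this place have therefore produced no readable number, and compound 4 is expected to behave in the same way. On this record, the expected change is a step that the limit leaves unreadable from compound 3 to compound 4 in this assay, with no firm direction and a strong chance of another limit. For compound 4 the estimated value is 30000 nM, expected to lie in the range from 12000 nM to 60000 nM.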

Compound 4, half-maximal effective concentration: > 21500 nM
Compound 4 gave a limit, no number; the forecaster's own chance of this, stated with the estimate: 85%; the middle value is on the limit's open side.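

Compound 4 gives only a limit in this assay, as do compound 1, compound 2 and compound 3, so no step among these four compounds can be read: the limit of > 21500 nM in this assay, at which 4 of the 4 values shown sit.

The compounds shown leave open whether any group at this place on the shared core would give a real number instead of a limit.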